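A few compounds are considered here, and "the series" means these few. Any claim that something is new, unique, unknown or untested is made for them only; others in the source may bear on it.

Measured compounds:
Compound 1 `O=C1c2ccccc2N(COCc2ccccc2)S(=O)(=O)N1Cc1ccccc1`: in a functional assay on HEL cells (Homo sapiens) for inhibition (a higher number here means that more compound is tolerated, a lower number that less compound is tolerated), compound 1 reads > 122000 nM, a limit of the assay.
Compound 2 `O=C1c2ccccc2N(COCc2ccccc2)S(=O)(=O)N1COCc1ccccc1`: in this assay compound 2 gives 130000 nM.
Compound 3 `O=C1c2ccccc2N(Cc2ccccc2Cl)S(=O)(=O)N1Cc1ccccc1Cl`: in this assay compound 3 reads > 200000 nM, a limit of the assay.

Compound 3 therefore stands only at a limit (the limit of > 200000 nM in this assay, at which 1 of the 3 values shown sits), and one further value among the three is likewise a limit (the limit of > 122000 nM in this assay, at which 1 of the 3 values shown sits). Compound 4 `O=C1c2ccccc2N(Cc2ccccc2Cl)S(=O)(=O)N1COCc1ccccc1` differs from compound 3 by benzyloxy in place of 2-chlorophenyl on a saturated chain carbon bound to an amide-type nitrogen in a ring. For the measured compounds named here, the only measured step that bears on this change, a step that the limit leaves unreadable from compound 1 to compound 2, is itself left unreadable by the limit, so its size is unknown. On what is shown, no step beyond the scatter is expected in this assay for this change. Compound 4 is estimated at 150000 nM (range 70000 nM to 300000 nM), which is expected to mean an at least 1.3-fold lower number from compound 3 to compound 4 (0.12 log units; that floor lies within the scatter), with a fair chance that only a limit is reported.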

Compound 4, half-maximal cytotoxic concentration: > 50000 nM
Compound 4 was reported as a limit (the forecaster's own chance of this, stated with the estimate: 60%); the middle value is on the limit's open side.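

Compound 4 stands only at a limit in this assay, and its steps to compound 2 and compound 3 cannot be read. Left open is what size of change, if any, benzyloxy in place of 2-chlorophenyl brings.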